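The source may hold more compounds than are shown below. What is called first, only, known or untested is meant among the compounds shown, and "the series" means these compounds.

Of the compounds shown here, three of a shared core have been measured in a functional assay on NCI-H1299 cells (Homo sapiens) for cytotoxicity, read by MTT assay, with a stated time of 48 h; a higher number here means a weaker inhibitor, a lower number a stronger inhibitor. Compound 1 `O=C1C[C@H](OCc2cn(-c3ccc([N+](=O)[O-])cc3)nn2)[C@H]2CO[C@@H]1O2` gives 10300 nM in this assay. Compound 2 `O=C1C[C@H](OCc2cn(C3CCCCC3)nn2)[C@H]2CO[C@@H]1O2` gives 12000 nM in this assay. Compound 3 `O=C1C[C@H](OCc2cc(-c3ccccc3)no2)[C@H]2CO[C@@H]1O2` gives 9800 nM in this assay, the lowest of the three numbers, though its gaps to compound 1 and to compound 2 both fall within the usual scatter, so no order among the three can be read from them.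

Compound 4 `O=C1C[C@H](OCc2cc(-c3ccc(Cl)cc3)no2)[C@H]2CO[C@@H]1O2` differs from compound 3 in one place: chloro in place of hydrogen on an aromatic carbon, a chloro in place of hydrogen on an aromatic carbon, para to a large group, so that the phenyl becomes a 4-chlorophenyl. Going by the values given here, no measured pair shows what such a change does on this core, and the three values so far stay close together. The step from compound 3 to compound 4 is therefore expected to be small, at most a modest move toward a lower number, a 1.2-fold lower number from compound 3 to compound 4 (0.09 log units; within the scatter), and not clearly beyond the scatter. Compound 4 is expected to give about 8000 nM in this assay, within a range from 3500 nM to 18000 nM.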

Compound 4, half-maximal inhibitory concentration: 9000 nM
Beside the measured number, compound 4's estimate is 1.1-fold (0.05 log units) below it; measured number inside the range.
By their numbers in this assay, from the lowest: compounds 4, 3, 1 and 2 (each within the scatter of the next).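

Going by these compounds alone, this is the first pair on the shared core that differs in one place, and in this assay chloro in place of hydrogen on an aromatic carbon, para to a large group, gives a 1.1-fold lower number from compound 3 to compound 4 (0.04 log units; within the scatter). So the change from phenyl to 4-chlorophenyl is accepted at this position without any shift that can be read from the scatter, and the single added chlorine does not separate compound 4 from compound 3. Nothing available bears on why the two compounds read alike.

The compounds shown leave open whether a different group at this position, such as an amine, a carboxylic acid or a longer chain, would move the number beyond the scatter. They also leave open whether the same chloro change would read alike on a compound built like compound 2.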